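A few compounds are considered here, and "the series" means these few. Any claim that something is new, unique, unknown or untested is made for them only; others in the source may bear on it.

Working notes on the series, starting from compound 1 `CCOc1ccccc1-c1ccc(-c2nc3cnccc3c(N[C@H](CC)C(=O)N(C)C)c2C#N)cc1`. In a physicochemical assay for lipophilicity, read by HPLC, at pH 7.5 (on this read-out lower numbers stand for lower lipophilicity and higher numbers for higher lipophilicity), compound 1 gives 3.7, the higher of the two numbers available. Among the compounds with values here, the only other measured member is compound 2 `CC[C@@H](Nc1c(C#N)c(-c2ccc(-c3ccc(OC)cc3)cc2)nc2cnccc12)C(N)=O`. In this assay compound 2 gives 2.7, and the gap between the two values lies beyond the usual scatter. Compound 1 and compound 2 differ in more than one place, so their gap cannot be read as the effect of any single change.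

The next member is compound 3 `CCOc1ccccc1-c1ccc(-c2nc3cnccc3c(N[C@H](CC)C(=O)NS(C)(=O)=O)c2C#N)cc1`, not yet measured. Its change from compound 1 is methanesulfonamido in place of dimethylamino on a carbonyl carbon. In words, methanesulfonamido stands in place of dimethylamino on a carbonyl carbon, which also reads as dimethylcarbamoyl to (methylsulfonyl)carbamoyl. Within the data shown here, no measured pair isolates a change at this place, so the expectation rests on the structural change alone and stays uncertain. A clear fall in this assay, well beyond the scatter, is expected. The expected step is a number 2.00 log units lower from compound 1 to compound 3 (beyond the scatter). For compound 3 the estimated value is 1.7, with an expected range of 0.9 to 2.6.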

Compound 3, distribution coefficient: 2.2
Beside the measured number, compound 3's estimate is 0.50 log units below it; the range from low to high includes it.
By their numbers in this assay, from the lowest: compound 3; then compound 2; then compound 1.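

With the rest of compound 1 held constant, the first change isolated at this place gives in this assay a number 1.50 log units lower from compound 1 to compound 3 (beyond the scatter), so the group on this carbonyl carbon can by itself move the read-out by a large step. The step goes with the exchange of dimethylamino, which has no hydrogen-bond donor or acceptor on the count used here, for methanesulfonamido, which has both, but a single pair cannot separate the contributions of the sulfonyl part, the methyl and the amide hydrogen. No separate measurement on hand bears on what lies behind this step.

Left open is where a carboxylic acid or a simple methylamino on the same carbonyl carbon would fall in this assay on the core of compound 1, and such neighbours would show how much of the step belongs to the sulfonyl part. Also open, as far as these compounds go, is whether the same exchange gives a step of similar size when the ethoxy-bearing end of compound 1 is replaced by the methoxy-bearing end seen in compound 2.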